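The source may report more compounds than this note shows. Statements on the series, on what has been measured and on what is new or still open speak of the compounds shown alone.

Among the measured compounds shown here, in a functional assay on NIH3T3 cells (Mus musculus) (on this read-out higher numbers stand for an effect only at larger amounts of compound and lower numbers for an effect already at smaller amounts), compound 2 `Cn1cncc1C(OCc1ccc(C#N)cc1C#Cc1ccccc1)c1ccc(C#N)cc1` gives 0.1 nM, the lower of the two numbers known so far. For the measured compounds named here, the only other measured compound, compound 1 `Cn1cncc1C(OCc1ccc(C#N)cc1C#Cc1ccc([N+](=O)[O-])cc1)c1ccc(C#N)cc1`, gives 36 nM. Going by the values given here, the single measured step, a 360-fold lower number from compound 1 to compound 2 (2.56 log units; beyond the scatter), is large and comes from hydrogen in place of nitro on an aromatic carbon. Compound 3 `Cn1cncc1C(OCc1ccc(C#N)cc1C#CCCc1ccccc1)c1ccc(C#N)cc1` differs from compound 2 in another way: phenethyl in place of phenyl on a triple-bonded carbon. Among the compounds with values here, no measured step covers this change, so the step from compound 1 bears on it only indirectly, showing that a single change in this part of the structure can shift this assay widely. With compound 2 at the low end, a moderate rise is expected, though with much uncertainty. The expected step is a 15-fold higher number from compound 2 to compound 3 (1.18 log units; beyond the scatter). For compound 3 the estimated value is 1.5 nM, with an expected range from 0.2 nM to 15 nM.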

Compound 3, half-maximal effective concentration: 130 nM
For compound 3 the middle estimate is 87-fold (1.94 log units) below the measured one; the measured number lies above the stated range.
By their numbers in this assay, from the lowest: compound 2; then compound 1; then compound 3.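

In this assay the change from phenyl to phenethyl on the triple-bonded carbon keeps the aromatic ring and adds carbon only, yet it gives a 1300-fold higher number from compound 2 to compound 3 (3.11 log units; beyond the scatter) and shows that this position responds strongly even to a change that brings in no hydrogen-bond donor, acceptor or charge. Compound 2 with its plain phenyl now stands lowest of the three, and phenethyl ends above 4-nitrophenyl too, with a 3.6-fold higher number from compound 1 to compound 3 (0.56 log units; beyond the scatter) as a modest step. Nothing at hand explains these shifts. From the compounds shown here alone, it remains open whether a benzyl group or a longer chain on the triple-bonded carbon would give a number near that of compound 2 or a still higher one. Going by these compounds, it also remains open how a methoxy group or an amine on the phenyl ring, in place of nitro, would read.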